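Swapping cyano for nitro on compound 2

This account rests on a few compounds, and the source may have more. Where it says the series, first, only, none or still open, it means among the compounds named here.

In a functional assay on DU-145 cells (Homo sapiens) for antiproliferative activity, read by propidium iodide staining, with a stated time of 96 h (a higher number here means a weaker inhibitor, a lower number a stronger inhibitor), compound 2 `CC(O)(CSc1ccc(S(F)(F)(F)(F)F)cc1)C(=O)Nc1ccc(C#N)cc1C(F)(F)F` gives 17700 nM. Compound 1 `CC(O)(CSc1ccc(S(F)(F)(F)(F)F)cc1)C(=O)Nc1ccc([N+](=O)[O-])c(C(F)(F)F)c1` gives 13900 nM, which lies within the usual scatter of compound 2, so the two cannot be told apart. Compound 3 `CC(O)(CSc1cccc(S(F)(F)(F)(F)F)c1)C(=O)Nc1ccc(C#N)cc1C(F)(F)F` gives 37400 nM, a number beyond the scatter from compound 2 and on the weaker side. Compound 4 `CC(O)(CSc1ccc(S(F)(F)(F)(F)F)cc1)C(=O)Nc1ccc([N+](=O)[O-])cc1C(F)(F)F` is still unmeasured. It has nitro in place of cyano on an aromatic carbon. Compound 1, which also carries a nitro group, stands at 13900 nM, so no step beyond the scatter is expected in this assay. The estimated change is a 1.2-fold lower number from compound 2 to compound 4 (0.07 log units; within the scatter). For compound 4 the expected value is 15000 nM, with an estimated range of 7000 nM to 32000 nM.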

Compound 4, half-maximal inhibitory concentration: 14500 nM
The estimate for compound 4 lay 1.0-fold (0.01 log units) above the measured number; measured number inside the range.
By their numbers in this assay, from the lowest: compounds 1, 4 and 2 (each within the scatter of the next); then compound 3.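

In this assay, among these compounds, the step of a 1.2-fold lower number from compound 2 to compound 4 (0.09 log units; within the scatter) is the first comparison here in which only one place differs, and it shows that cyano and nitro cannot be told apart at this position on the shared core. Compound 1 also carries nitro, but it differs from compound 2 in more than one place, so it could not show this directly. As far as these compounds go, what an amine or a carboxylic acid in this place would give stays open. No measured property at hand bears on this result.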